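Compound 3 to compound 4: a smaller amide substituent

A few compounds are considered here, and "the series" means these few. Any claim that something is new, unique, unknown or untested is made for them only; others in the source may bear on it.

In a physicochemical assay for solubility (on this read-out lower numbers stand for lower solubility and higher numbers for higher solubility), compound 1 `CNC(=O)c1cc(C(=O)N[C@H]2[C@@H]3C[C@@H](O)C[C@@H]32)cc2c1OC[C@H]2c1ccccc1` gives >= 124 ug/mL as a limit. Compound 2 `CNC(=O)c1cc(C(=O)Nc2cnn(C)c2)cc2c1OC[C@H]2c1ccccc1` gives >= 189 ug/mL as a limit too. Compound 3 `CNC(=O)c1cc(C(=O)NC2CC2)cc2c1OC[C@H]2c1ccccc1` stands at >= 190 ug/mL as a limit and not a number. Compound 4 `CNC(=O)c1cc(C(=O)NC)c2c(c1)[C@H](c1ccccc1)CO2` follows from compound 3 through methyl in place of cyclopropyl on an amide-type nitrogen with methyl in place of cyclopropyl on an amide-type nitrogen. Bearing on this are a step that the two limits leave unreadable from compound 2 to compound 3 and a step that the two limits leave unreadable from compound 1 to compound 3 and a step that the two limits leave unreadable from compound 1 to compound 2 with no size to carry over. No step beyond the scatter is therefore expected in this assay and no direction is favoured. The estimate means a number no higher from compound 3 to compound 4 (the limit leaves the size open) as the expected step. Compound 4 is estimated at 190 ug/mL with a range of 110 ug/mL to 260 ug/mL and may again read as a limit.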

Compound 4, solubility: >= 130 ug/mL
Compound 4 was reported as a limit; the forecaster's own chance of this, stated with the estimate: 75%; the middle value lies beyond the limit too.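

In this assay, for the compounds shown here, compound 1, compound 2, compound 3 and compound 4 all read as limits and not numbers, so no step among them can be read. The compounds shown leave open how far each true solubility lies past its limit, and whether methyl in place of cyclopropyl on the amide-type nitrogen moves it at all.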